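The source may report more compounds than this note shows. Statements on the series, on what has been measured and on what is new or still open speak of the compounds shown alone.

In a functional assay on NCI/ADR-RES cells (Homo sapiens) for inhibition, read by sulforhodamine B assay, with a stated time of 48 h, tested at 1 uM (a lower number here means a stronger effect, a higher number a weaker effect of the compound at the concentration tested), compound 3 `COc1cc(Cl)cc(-c2nn(-c3cccc(NC(=O)Nc4cc(C(F)(F)F)cc(C(F)(F)F)c4)c3)cc2-c2ccncc2)c1` gives 48%, the lowest of the three numbers recorded and beyond the scatter from both of the others: compound 2 `O=C(Nc1cccc(-n2cc(-c3ccncc3)c(-c3cc(O)cc(Cl)c3)n2)c1)Nc1ccc(Cl)c(Cl)c1` gives 90% and compound 1 `O=C(Nc1cccc(-n2cc(-c3ccncc3)c(-c3cc(O)cc(Cl)c3)n2)c1)Nc1ccc(Cl)c(C(F)(F)F)c1` gives 97%. Compound 4 `COc1cc(Cl)cc(-c2nn(-c3cccc(NC(=O)Nc4cccc(C(F)(F)F)c4)c3)cc2-c2ccncc2)c1` differs from compound 3 by hydrogen in place of trifluoromethyl on an aromatic carbon. Within the data shown here, the only measured step, a number 7 percentage points lower from compound 1 to compound 2 (within the scatter), concerns a different change and lies within the scatter, so it gives no direct guide. Compounds 1 and 2 carry at most one trifluoromethyl and sit high, but each also differs from compound 3 elsewhere, so the pattern rests on a single compound. Compound 4 is therefore expected to keep less of the effect of compound 3, a step of a number 24 percentage points higher from compound 3 to compound 4 (beyond the scatter), with an estimated 72% and a range from 48% to 96%.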

Compound 4, a percentage reported as activity, at one concentration (the size of the read-out at that concentration, not a potency): 65%
The estimate for compound 4 lay 7 percentage points above the measured number; measured number inside the range.
By their numbers in this assay, from the lowest: compound 3; then compound 4; then compounds 2 and 1 (each within the scatter of the next).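

Among these compounds, with this assay as the read-out, this is the first direct reading of the place on the aromatic carbon meta to a trifluoromethyl group, where hydrogen replaces trifluoromethyl. The change gives a number 17 percentage points higher from compound 3 to compound 4 (beyond the scatter), so the second trifluoromethyl matters to the effect at the concentration tested, although the size of the step is modest. Nothing measured here accounts for this step. The compounds shown leave open whether an amine or a nitrile on this carbon would keep the number of compound 3. They also leave open how the remaining trifluoromethyl of compound 4 contributes.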